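Benzyl for 2-fluorophenyl on the amine of compound 1

The source may hold more compounds than are shown below. What is called first, only, known or untested is meant among the compounds shown, and "the series" means these compounds.

Measured compounds:
- compound 1 `O=C1C(Nc2ccccc2F)=CC(=O)c2c1nc1n2[C@H]2OC[C@@H](O)[C@H]2OC1`: 2000 nM
- compound 2 `O=C1C=C(N2CCC2)C(=O)c2c1nc1n2[C@H]2OC[C@@H](O)[C@H]2OC1`: > 16000 nM

Among the measured compounds shown here, in a functional assay on MGC-803 cells (Homo sapiens) for inhibition, read by sulforhodamine B assay (a higher number here means a weaker inhibitor, a lower number a stronger inhibitor), compound 1 gives 2000 nM, the only number among the values shown. Compound 2 reaches only a limit of the assay, > 16000 nM; the limit is described by the limit of > 16000 nM in this assay, at which 1 of the 2 values shown sits. Compound 3 `O=C1C(NCc2ccccc2)=CC(=O)c2c1nc1n2[C@H]2OC[C@@H](O)[C@H]2OC1` differs from compound 1 by benzyl in place of 2-fluorophenyl on an amine nitrogen. For the measured compounds named here, no step between two measured compounds is available, so the size of this change is unknown; in this assay a step in either direction not much beyond the scatter is expected. For compound 3 a value of 3000 nM is estimated, between 800 nM and 12000 nM, so that the expected step is a 1.5-fold higher number from compound 1 to compound 3 (0.18 log units; within the scatter).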

Compound 3, half-maximal inhibitory concentration: 3490 nM
For compound 3 the middle estimate is 1.2-fold (0.07 log units) below the measured one; the measured number falls inside the stated range.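

Among the compounds shown here, the first measured step at this amine nitrogen, a 1.7-fold higher number from compound 1 to compound 3 (0.24 log units; within the scatter) in this assay, shows that benzyl and 2-fluorophenyl cannot be told apart here. For this pair, then, neither a fluorine nor a ring bonded directly to the nitrogen is needed to keep the activity of compound 1. Nothing measured here gives a cause for this outcome. As far as these compounds go, the swap removes the fluorine and alters the ring's attachment together, so the part each plays stays open. From the compounds shown here alone, it is also open how a plain phenyl, a phenethyl chain or a carboxylic acid on the benzyl ring would read.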